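The source may report more compounds than this note shows. Statements on the series, on what has been measured and on what is new or still open speak of the compounds shown alone.

Three compounds share one core and differ only in the aromatic group attached to a double-bonded chain carbon bound to a double-bonded ring carbon. Compound 1 `CC(=O)OC[C@H]1O[C@@H](n2cc(CN3C(=O)/C(=C/c4ccc(C)cc4)c4ccccc43)nn2)[C@H](OC(C)=O)[C@@H](OC(C)=O)[C@@H]1OC(C)=O` carries a 4-methylphenyl group at that place, compound 2 `CC(=O)OC[C@H]1O[C@@H](n2cc(CN3C(=O)/C(=C/c4ccc(N(C)C)cc4)c4ccccc43)nn2)[C@H](OC(C)=O)[C@@H](OC(C)=O)[C@@H]1OC(C)=O` a 4-(dimethylamino)phenyl group, and compound 3 `CC(=O)OC[C@H]1O[C@@H](n2cc(CN3C(=O)/C(=C/c4ccc5ccccc5c4)c4ccccc43)nn2)[C@H](OC(C)=O)[C@@H](OC(C)=O)[C@@H]1OC(C)=O` a naphthalen-2-yl group. In a functional assay on A549 cells (Homo sapiens) for cytotoxicity, read by sulforhodamine B assay, with a stated time of 48 h (on this read-out lower numbers stand for stronger inhibition and higher numbers for weaker inhibition), compound 1 gives 16000 nM, compound 2 gives 19400 nM, and compound 3 gives 30900 nM. The steps of a 1.2-fold higher number from compound 1 to compound 2 (0.08 log units; within the scatter), a 1.9-fold higher number from compound 1 to compound 3 (0.29 log units; within the scatter) and a 1.6-fold higher number from compound 2 to compound 3 (0.20 log units; within the scatter) all lie within the scatter of this assay, so none of the three compounds stands apart from the others; compound 3 simply sits among them.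

Compound 4 `CC(=O)OC[C@H]1O[C@@H](n2cc(CN3C(=O)/C(=C/c4cccs4)c4ccccc43)nn2)[C@H](OC(C)=O)[C@@H](OC(C)=O)[C@@H]1OC(C)=O` continues the same theme: thiophen-2-yl in place of naphthalen-2-yl on a double-bonded chain carbon bound to a double-bonded ring carbon. Two of the measured steps change the group at exactly this place, and both, a 1.9-fold higher number from compound 1 to compound 3 (0.29 log units; within the scatter) and a 1.6-fold higher number from compound 2 to compound 3 (0.20 log units; within the scatter), stayed within the scatter. With three different aromatic groups at this place yielding much the same number, a fourth aromatic group is expected to behave alike. Compound 4 is therefore expected to show a step of a 1.2-fold lower number from compound 3 to compound 4 (0.09 log units; within the scatter) in this assay, which is none beyond the scatter. Compound 4 is estimated at 25000 nM, with a range from 10000 nM to 60000 nM.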

Compound 4, half-maximal inhibitory concentration: 20800 nM
Compound 4: middle estimate off by 1.2-fold (0.08 log units), on the high side; measured number inside the range.
By their numbers in this assay, from the lowest: compounds 1, 2, 4 and 3 (each within the scatter of the next).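

In this assay, the place on a double-bonded chain carbon bound to a double-bonded ring carbon also tolerates a five-membered aromatic ring with 1 hetero atom. Thiophen-2-yl has fewer heavy atoms than naphthalen-2-yl, yet the change gives only a small step (a 1.5-fold lower number from compound 3 to compound 4 (0.17 log units; within the scatter)), and the comparisons with the two substituted phenyl groups read the same way (a 1.1-fold higher number from compound 2 to compound 4 (0.03 log units; within the scatter) and a 1.3-fold higher number from compound 1 to compound 4 (0.11 log units; within the scatter)), so among these four compounds neither the size of the aromatic group nor a sulfur atom in its ring separates the numbers. The information shown offers no explanation for why the numbers stay so close.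

All four groups at this place are aromatic, so the compounds shown leave open whether a cyclohexyl ring, a plain alkyl chain, or a group carrying a carboxylic acid or an amine would move the number beyond the scatter. The rest of the shared core is also identical in all four compounds, so they cannot show whether changes elsewhere would matter more than changes at this place.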